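The source may hold more compounds than are shown below. What is called first, only, known or untested is meant among the compounds shown, and "the series" means these compounds.

Compound 2 `CCOC(=O)c1sc(-c2cccc(NC(=O)c3ccc(C#N)cc3)c2)nc1Nc1ccc(N2CCN(C)CC2)cc1` stands highest of the two numbers measured in a functional assay on Ramos cells (Homo sapiens) for antiproliferative activity, read by CCK-8 assay, with a stated time of 72 h, tested at 40 uM (a lower number here means less inhibition, a higher number more inhibition at the concentration tested (going by the name of the read-out)), where compound 2 gives 97.5% and compound 1 `CCOC(=O)c1sc(-c2cccc(NC(=O)c3ccc(C(F)(F)F)cc3)c2)nc1Nc1ccc(N2CCN(C)CC2)cc1` gives 18.4%. For the measured compounds named here, the one measured step, a number 79.1 percentage points higher from compound 1 to compound 2 (beyond the scatter), swaps a group on the aromatic ring but keeps that ring. Compound 3 `CCOC(=O)c1sc(-c2cccc(NC(=O)[C@H]3CC[C@H](C)CC3)c2)nc1Nc1ccc(N2CCN(C)CC2)cc1` differs from compound 2 by 4-methylcyclohexyl in place of 4-cyanophenyl on a carbonyl carbon. Going by the values given here, no measured step removes the 4-cyanophenyl ring itself, so the step from compound 1 to compound 2 bears on this change only loosely, and the expectation is wide. Compound 3 is expected to show a step of a number 52.5 percentage points lower from compound 2 to compound 3 (beyond the scatter). Compound 3 is estimated at 45%, within 10% to 85%.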

Compound 3, a percentage reported as inhibition, at one concentration (the size of the read-out at that concentration, not a potency): 19.9%
For compound 3 the middle estimate is 25.1 percentage points above the measured one, within the range that was stated.
By their numbers in this assay, from the lowest: compounds 1 and 3 (each within the scatter of the next); then compound 2.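

Replacing the aromatic ring itself on the carbonyl carbon now has a direct reading in this assay as a number 77.6 percentage points lower from compound 2 to compound 3 (beyond the scatter) and the high value of compound 2 does not carry over to 4-methylcyclohexyl. Against 4-(trifluoromethyl)phenyl, the same 4-methylcyclohexyl gives a number 1.5 percentage points higher from compound 1 to compound 3 (within the scatter) so among these three compounds only 4-cyanophenyl stands apart. Nothing available explains this difference.

Open, on these data alone, is whether the nitrile needs the aromatic ring. A 4-cyanocyclohexyl group, or a 4-aminophenyl or 4-carboxyphenyl group, on the same carbonyl carbon would separate the two.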